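A Hydroxyphenyl Swap on a Core That Tolerates Much

The compounds below may be only part of what the source reports. "The series", "measured", "known", "first", "only" and "open" are said of these compounds alone.

Of the compounds shown here, three measured so far share one core and differ in a single group. Compound 1 is `Cc1nc(-c2cccnc2)sc1-c1nnc(-c2ccc(Br)cc2)o1`, compound 2 is `Cc1nc(-c2cccnc2)sc1-c1nnc(-c2cccnc2)o1` and compound 3 is `Cc1nc(-c2cccnc2)sc1-c1nnc(Cc2ccccc2)o1`. In an ADME assay on HCT-116 cells (Homo sapiens) for cytotoxicity, read by MTT assay (a higher number here means that more compound is tolerated, a lower number that less compound is tolerated), compound 1 gives > 100 ug/mL, which is a limit of the assay rather than a number. In this assay compound 2 gives > 100 ug/mL, again a limit. In this assay compound 3 gives > 100 ug/mL, also a limit. Because of the limit of > 100 ug/mL in this assay, at which 3 of the 3 values shown sit, none of the steps between these compounds can be read: a step that the two limits leave unreadable from compound 1 to compound 2, a step that the two limits leave unreadable from compound 1 to compound 3 and a step that the two limits leave unreadable from compound 2 to compound 3. Compound 3 therefore stands at the limit, with nothing that sets it apart from compound 1 or compound 2.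

Compound 4 is `Cc1nc(-c2cccnc2)sc1-c1nnc(-c2ccc(O)cc2)o1`, and it differs from compound 3 in one place: 4-hydroxyphenyl in place of benzyl on an aromatic carbon. Among the compounds with values here, no measured step has a readable size that could guide this change, since all three sit at the limit, so no step beyond the scatter is expected in either direction. Compound 4 is thus expected to give about 100 ug/mL, with an estimated range from 50 ug/mL to 200 ug/mL. The expected step of a number no higher from compound 3 to compound 4 (the limit leaves the size open) is estimated as no change beyond the scatter.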

Compound 4, half-maximal cytotoxic concentration: > 100 ug/mL
Compound 4 ended at the assay's limit (the forecaster's own chance of this, stated with the estimate: 75%); the middle value sits exactly at the limit.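

Within the data shown here, no step between compound 4 and compound 1, compound 2 or compound 3 can be read in this assay, because all four compounds end at the same limit: the limit of > 100 ug/mL in this assay, at which 4 of the 4 values shown sit.

The compounds shown leave open whether swapping the group on the shared core changes cell tolerance at all.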